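The compounds below may be only part of what the source reports. "The series", "measured", "known", "first", "only" and "open" are said of these compounds alone.

In an ADME assay on LLC-MK2 cells (Macaca mulatta) for cytotoxicity, read by spectrophotometry and crystal violet staining, with a stated time of 4 days (on this read-out lower numbers stand for higher toxicity in this test and higher numbers for lower toxicity in this test), compound 1 `CC(C)n1ncc2c(C(=O)Nc3ccc(F)c(F)c3)cc(-c3cccs3)nc21` gives > 200000 nM, and that value is a limit of the assay, not a number. Compound 2 `CC(C)n1ncc2c(C(=O)Nc3ccccc3F)cc(-c3cccs3)nc21` gives 50000 nM and compound 3 `CC(C)n1ncc2c(C(=O)Nc3cc(C(N)=O)ccc3F)cc(-c3cccs3)nc21` gives 25000 nM. Compound 3 therefore stands level with compound 2, since the gap between them is a 2.0-fold lower number from compound 2 to compound 3 (0.30 log units; within the scatter).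

The next step, to compound 4 `CC(C)n1ncc2c(C(=O)Nc3cccc(S(N)(=O)=O)c3)cc(-c3cccs3)nc21`, puts 3-sulfamoylphenyl in place of 5-carbamoyl-2-fluorophenyl on an amide-type nitrogen. Two measured changes at this same place were sizeable: an at least 4.0-fold lower number from compound 1 to compound 2 (0.60 log units; beyond the scatter) and an at least 8.0-fold lower number from compound 1 to compound 3 (0.90 log units; beyond the scatter). These show that the group on that nitrogen can move this assay, so the range for compound 4 has to stay wide. The closest comparison, however, is the addition of carbamoyl, which gave only a 2.0-fold lower number from compound 2 to compound 3 (0.30 log units; within the scatter). Within the data shown here, no measured compound carries the sulfamoyl group, so the expectation is no clear shift in either direction. The expected change is a 1.4-fold higher number from compound 3 to compound 4 (0.15 log units; within the scatter). Compound 4 is estimated at about 35000 nM, with an expected range of 12000 nM to 120000 nM.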

Compound 4, half-maximal cytotoxic concentration: 25000 nM
Compound 4: middle estimate off by 1.4-fold (0.15 log units), on the high side; the range from low to high includes it.
By their numbers in this assay, from the lowest: compounds 3, 4 and 2 (each within the scatter of the next). At a limit, above all of these: compound 1.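

Putting 3-sulfamoylphenyl in place of 5-carbamoyl-2-fluorophenyl on the amide-type nitrogen exchanges the carbamoyl group for a sulfamoyl group and also removes the fluorine, yet this assay shows no readable shift (no change at the digits printed from compound 3 to compound 4 (within the scatter)). The new group also stands level with 2-fluorophenyl (a 2.0-fold lower number from compound 2 to compound 4 (0.30 log units; within the scatter)), so compounds 2, 3 and 4 form one group, and among the compounds shown only 3,4-difluorophenyl stands apart (an at least 8.0-fold lower number from compound 1 to compound 4 (0.90 log units; beyond the scatter)). That step has no exact size because compound 1 sits at a limit of the assay: the limit of > 200000 nM in this assay, at which 1 of the 4 values shown sits.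

This swap changes two things at once, so the sulfamoyl group and the loss of fluorine cannot be judged separately. A 3-carbamoylphenyl group would help separate them, while an amine or a carboxylic acid on this phenyl ring remains an open question.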